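Second Methyl on the Saturated Ring of Compound 2

This account rests on a few compounds, and the source may have more. Where it says the series, first, only, none or still open, it means among the compounds named here.

Compound 2 `CC1CN(C2=CCCC2=O)c2cc(C(F)(F)F)ccc2S1` gives, in a functional assay on aorta (Rattus norvegicus, strain Wistar) (on this read-out higher numbers stand for larger maximal responses and lower numbers for smaller maximal responses), 94%, the lower of the two numbers in hand, yet compound 1 `CC1(C)CN(C2=CCCC2=O)c2cc(N)ccc2S1` gives 96%, which lies within the scatter of that result. Compound 3 `CC1(C)CN(C2=CCCC2=O)c2cc(C(F)(F)F)ccc2S1` is compound 2 changed by methyl in place of hydrogen on a saturated ring carbon. Compound 1 already carries the doubly methylated saturated ring and still reaches 96%, so no step beyond the scatter is expected; the step expected is a number 1 percentage points higher from compound 2 to compound 3 (within the scatter). Compound 3 is estimated at 95%, between 84% and 104%.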

Compound 3, largest response reached (Emax), in percent of the reference or control that the assay uses: 92%
Beside the measured number, compound 3's estimate is 3 percentage points above it; low and high end bracket the measured number.
By their numbers in this assay, from the lowest: compounds 3, 2 and 1 (each within the scatter of the next).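

In this assay, methyl in place of hydrogen on a saturated ring carbon, next to the ring sulfur, gives a number 2 percentage points lower from compound 2 to compound 3 (within the scatter) and so leaves the maximal response within the scatter at this position. With the doubly methylated saturated ring held in common, trifluoromethyl in place of amino on an aromatic carbon gives a number 4 percentage points lower from compound 1 to compound 3 (within the scatter) and likewise stays within the scatter. No measured property bears on either step. As far as these compounds go, whether an ethyl group on this saturated ring carbon, or a carboxylic acid in place of trifluoromethyl on the aromatic carbon, would keep the response this close remains open.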